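The source may report more compounds than this note shows. Statements on the series, on what has been measured and on what is new or still open speak of the compounds shown alone.

The measured compounds in an assay on MDA-MB-231 cells for binding affinity to C-X-C chemokine receptor type 4 (Homo sapiens), read by immunofluorescence and microscopy, with stated times of 10 min and 30 min; a lower number here means that less compound is needed, a higher number that more compound is needed for the effect:

Compound 1 `Cc1ccc(S(=O)(=O)NCc2ccc(CNC(=O)c3ccccc3)cc2)cc1` gives > 1000 nM, a limit of the assay and not a number.
Compound 2 `COc1ccccc1C(=O)NCc1ccc(CNS(=O)(=O)c2ccccc2)cc1` gives 1 nM.
Compound 3 `COc1ccccc1C(=O)NCc1ccc(CNS(=O)(=O)c2ccc(C)cc2)cc1` gives 100 nM.

Compound 2 stands with the lowest of the two numbers measured. Its nearest neighbour is compound 3: the step of a 100-fold higher number from compound 2 to compound 3 (2.00 log units; beyond the scatter) is large and beyond the scatter, and it comes from methyl in place of hydrogen on an aromatic carbon. The other measured step, an at least 10-fold lower number from compound 1 to compound 3 (1.00 log units; beyond the scatter), sets out from a value that sits at the limit of > 1000 nM in this assay, at which 1 of the 3 values shown sits, and shows methoxy in place of hydrogen on an aromatic carbon giving an at least modest lowering.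

Compound 4 `O=C(NCc1ccc(CNS(=O)(=O)c2ccccc2)cc1)c1ccncc1` has not yet been measured in this assay. It differs from compound 2 by pyridin-4-yl in place of 2-methoxyphenyl on a carbonyl carbon. Neither measured step covers this exchange directly; the one that bears on it is an at least 10-fold lower number from compound 1 to compound 3 (1.00 log units; beyond the scatter), since compound 4 gives up the methoxy group together with the ring that carried it. A step upward, beyond the scatter, is therefore expected, shown as a 30-fold higher number from compound 2 to compound 4 (1.48 log units; beyond the scatter). For compound 4 the estimate is 30 nM, within 3 nM to 300 nM.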

Compound 4, effective concentration (reported as EC, without a stated level of effect): 10 nM
For compound 4 the middle estimate is 3.0-fold (0.48 log units) above the measured one; the range from low to high includes it.
By their numbers in this assay, from the lowest: compound 2; then compound 4; then compound 3. At a limit, above all of these: compound 1.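

Where the earlier steps changed a single substituent on an aromatic carbon, this exchange replaces the whole ring on the carbonyl carbon, and in this assay it gives a 10-fold higher number from compound 2 to compound 4 (1.00 log units; beyond the scatter). The position therefore responds to a change of ring, yet compound 4, with pyridin-4-yl and no methoxy group, still gives 10 nM, a measured number and not a limit. Nothing measured here accounts for the size of this step.

The compounds shown do not separate the loss of the methoxy group from the entry of the ring nitrogen, since both change together in this one exchange. From the compounds shown here alone, how this position would respond to a saturated piperidine ring, or to an amine or a carboxylic acid on the ring, remains open.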